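Moving one methyl group: compound 3 to compound 4

The source may report more compounds than this note shows. Statements on the series, on what has been measured and on what is new or still open speak of the compounds shown alone.

In an in vitro ADME assay on microsomes from liver (Canis lupus familiaris) for metabolic stability (on this read-out higher numbers stand for fast clearance and lower numbers for slow clearance), compound 1 (`CCC(CC)[C@@H]1C(=O)N[C@H](C2Cc3ccccc3C2)C(=O)N1[C@@H](C(=O)N1CCOCC1)c1ccc(C)nc1`) reads 5 mL.min-1.g-1 and compound 2 (`Cc1ccc([C@H](C(=O)N(C)C)N2C(=O)[C@@H](C3Cc4ccccc4C3)NC(=O)[C@H]2CC(C)C)cn1`) reads 3000 mL.min-1.g-1 on the same scale. Compound 3 (`CC[C@H](C)[C@@H]1C(=O)N[C@H](C2Cc3ccccc3C2)C(=O)N1[C@@H](C(=O)N(C)C)c1ccc(C)nc1C`) stands lowest of the three at 1 mL.min-1.g-1 and lies beyond the scatter from both. Compound 4 (`CC[C@H](C)[C@@H]1C(=O)N[C@H](C2Cc3ccccc3C2)C(=O)N1[C@@H](C(=O)N(C)C)c1cc(C)cnc1C`) has the same atoms joined differently, with 2,5-dimethylpyridin-3-yl in place of 2,6-dimethylpyridin-3-yl on a saturated chain carbon bound to an amide-type nitrogen in a ring and a carbonyl carbon. Among the measured compounds shown here, no measured pair shows this kind of change. In this assay a modest rise is expected, an estimated step of a 3.0-fold higher number from compound 3 to compound 4 (0.48 log units; beyond the scatter) of uncertain size. For compound 4 the estimate is 3 mL.min-1.g-1 within an expected range of 1 mL.min-1.g-1 to 20 mL.min-1.g-1 on this read-out.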

Compound 4, intrinsic clearance in microsomes: 2 mL.min-1.g-1
Estimate against measurement, compound 4: 1.5-fold (0.18 log units) above; measured number inside the range.
By their numbers in this assay, from the lowest: compounds 3 and 4 (each within the scatter of the next); then compound 1; then compound 2.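

In this assay, 2,5-dimethylpyridin-3-yl in place of 2,6-dimethylpyridin-3-yl gives a 2.0-fold higher number from compound 3 to compound 4 (0.30 log units; within the scatter) and so leaves the read-out unchanged within the scatter at this position. This is the first pair shown that differs in one place, and it shows that the methyl group can move on this ring without a readable change. Nothing measured here bears on the reason for this result. The compounds shown leave open whether an amine or a carboxylic acid in place of that methyl group would give a similar number. They also leave open how a longer chain there would read.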